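Moving the fluorine on the benzyl ring of compound 3

The source may report more compounds than this note shows. Statements on the series, on what has been measured and on what is new or still open speak of the compounds shown alone.

Compound 3 `O=C(O)c1ccccc1-c1ccc(CCc2ncc(Cc3cccc(F)c3)[nH]2)cc1` gives the lowest number of the three compounds measured in an in vitro functional assay on cells for agonist activity at Bombesin receptor subtype-3 (Homo sapiens), read by luminescence and calcium flux; a higher number here means that more compound is needed for the effect, a lower number that less compound is needed: compound 3 gives 159 nM, compound 1 `O=C(O)c1ccccc1-c1ccc(CCc2ncc(CC3CCC3)[nH]2)cc1` gives 588 nM, and compound 2 `O=C(O)c1ccccc1-c1ccc(CCc2ncc(Cc3ccc(Cl)cc3)[nH]2)cc1` gives 2290 nM. Compound 4 `O=C(O)c1ccccc1-c1ccc(CCc2ncc(Cc3ccc(F)cc3)[nH]2)cc1` differs from compound 3 by 4-fluorophenyl in place of 3-fluorophenyl on a saturated chain carbon bound to an aromatic carbon. Among the measured compounds shown here, no measured step swaps one fluorophenyl for another, so the bearing steps are indirect: a 14-fold lower number from compound 2 to compound 3 (1.16 log units; beyond the scatter) and a 3.7-fold lower number from compound 1 to compound 3 (0.57 log units; beyond the scatter), while a 3.9-fold higher number from compound 1 to compound 2 (0.59 log units; beyond the scatter). These show a 4-chlorophenyl group giving a higher number than the 3-fluorophenyl group, which suggests the 4-fluorophenyl group may also give a higher number, though the halogen also changes. The expected step in this assay for compound 4 is a 2.8-fold higher number from compound 3 to compound 4 (0.45 log units; beyond the scatter), a modest rise. Compound 4 is therefore estimated at 450 nM, within a range from 150 nM to 1500 nM.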

Compound 4, half-maximal effective concentration: 1600 nM
For compound 4 the middle estimate is 3.6-fold (0.55 log units) below the measured one; measured number above the stated range.
By their numbers in this assay, from the lowest: compound 3; then compound 1; then compounds 4 and 2 (each within the scatter of the next).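

Moving the fluorine while keeping the same atoms gives a 10-fold higher number from compound 3 to compound 4 (1.00 log units; beyond the scatter), so where the halogen sits on this ring matters, not merely that one is present. Changing the halogen itself gives a 1.4-fold lower number from compound 2 to compound 4 (0.16 log units; within the scatter), a step within the scatter. Replacing cyclobutyl gives a 2.7-fold higher number from compound 1 to compound 4 (0.43 log units; beyond the scatter), so among these compounds only the 3-fluorophenyl group gives a lower number than cyclobutyl. Nothing here explains why the fluorine's place matters so much. Going by these compounds, whether a plain phenyl group or a methoxy-bearing phenyl group would give a lower number than the 3-fluorophenyl group remains open.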